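The source may hold more compounds than are shown below. What is called first, only, known or untested is meant among the compounds shown, and "the series" means these compounds.

Working notes on the series: in a functional assay on MCF7 cells (Homo sapiens) for cytotoxicity, read by sulforhodamine B assay, with a stated time of 24 h (a lower number here means a stronger inhibitor, a higher number a weaker inhibitor), compound 1 (`O=C1Nc2ccc(S(=O)(=O)N3CCOCC3)cc2/C1=N/c1ccc(O)cc1`) gives 52700 nM and compound 2 (`O=C1Nc2ccc(S(=O)(=O)N3CCOCC3)cc2/C1=N/c1ccc(C(=O)O)cc1`) gives 26700 nM while compound 3 (`CC(=O)c1cccc(/N=C2\C(=O)Nc3ccc(S(=O)(=O)N4CCOCC4)cc32)c1`) gives 39200 nM and so stands within the scatter of both. The move to compound 4 (`O=C1Nc2ccc(S(=O)(=O)N3CCOCC3)cc2/C1=N/NS(=O)(=O)c1ccccc1`) reads (phenylsulfonyl)amino in place of 3-acetylphenyl on a double-bonded nitrogen and puts (phenylsulfonyl)amino in place of 3-acetylphenyl on a double-bonded nitrogen. Changes on that nitrogen gave a 1.3-fold lower number from compound 1 to compound 3 (0.13 log units; within the scatter) and a 1.5-fold higher number from compound 2 to compound 3 (0.17 log units; within the scatter) while carboxy in place of hydroxy gave a 2.0-fold lower number from compound 1 to compound 2 (0.30 log units; within the scatter) in the same series. None of these steps brings in (phenylsulfonyl)amino, so they offer only loose guidance, and no step beyond the scatter is expected in this assay here. The expected step is a 1.1-fold lower number from compound 3 to compound 4 (0.05 log units; within the scatter) on this reading. Compound 4 is expected at 35000 nM with an estimated range of 12000 nM to 90000 nM for now.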

Compound 4, half-maximal inhibitory concentration: 25300 nM
Compound 4: middle estimate off by 1.4-fold (0.14 log units), on the high side; the range from low to high includes it.
By their numbers in this assay, from the lowest: compounds 4, 2, 3 and 1 (each within the scatter of the next, the first and the last beyond it).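

For the compounds shown here, on the double-bonded nitrogen, (phenylsulfonyl)amino is the first group that is not a substituted phenyl, and in this assay the change gives a 1.5-fold lower number from compound 3 to compound 4 (0.19 log units; within the scatter) and a 1.1-fold lower number from compound 2 to compound 4 (0.02 log units; within the scatter) as well as a 2.1-fold lower number from compound 1 to compound 4 (0.32 log units; beyond the scatter) in the only step here that passes the scatter. The series can therefore carry this sulfonyl-bearing group on that nitrogen, although the gain over the hydroxy compound stays modest. Nothing available explains these steps.

Open, as far as these compounds go, is whether an amine or a longer alkyl chain in place of the phenyl of (phenylsulfonyl)amino would hold these numbers or move them beyond the scatter.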